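The source may report more compounds than this note shows. Statements on the series, on what has been measured and on what is new or still open speak of the compounds shown alone.

Measured compounds:
Compound 1 `CCCc1nn(C)c2c(NCc3ccc(F)cc3)nc(/C=C/c3cccnc3)nc12` — in a functional assay on L02 cells (Homo sapiens) for inhibition, read by Griess assay, with stated times of 1 h and 24 h (a lower number here means a stronger inhibitor, a higher number a weaker inhibitor), compound 1 gives 940000 nM.
Compound 2 `COc1cc(/C=C/c2nc(N(C)C)c3sccc3n2)cc(OC)c1OC` — in this assay compound 2 gives only a limit of the assay, > 1000000 nM.

Compound 2 therefore stands at the edge of what this assay reports: its result is a limit and not a number, the one value of the two shown that sits there, (the limit of > 1000000 nM in this assay, at which 1 of the 2 values shown sits). Compound 1 gives a number, but no step between the two measured compounds is shown, since they differ in more than one place.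

Compound 3 `COc1cc(/C=C/c2nc(Nc3ccc(C(C)C)cc3)c3sccc3n2)cc(OC)c1OC` differs from compound 2 in a single place: (4-isopropylphenyl)amino in place of dimethylamino on an aromatic carbon. Among the compounds with values here, with no measured step to rest on, the size of this change can only be guessed. Compound 3 is expected to give roughly 600000 nM in this assay, with a range from 150000 nM to 3000000 nM. The expected step is an at least 1.6-fold lower number from compound 2 to compound 3 (0.22 log units; that floor lies within the scatter), a modest gain that may well not go beyond the usual scatter, and a limit result remains a real possibility.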

Compound 3, half-maximal inhibitory concentration: 370000 nM
Beside the measured number, compound 3's estimate is 1.6-fold (0.21 log units) above it, within the range that was stated.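

At the aromatic carbon next to the ring nitrogen, putting (4-isopropylphenyl)amino in place of dimethylamino gives an at least 2.7-fold lower number from compound 2 to compound 3 (0.43 log units; beyond the scatter) in this assay. Within the data shown here, this is the first single-place change that can be read, and it shows that the group at this position can move the result off the edge of the assay and onto a measured number, with compound 3 at 370000 nM. The true size of the step may be larger than printed, since compound 2 gives only a limit and not a number: the limit of > 1000000 nM in this assay, at which 1 of the 3 values shown sits.

The change swaps a small dialkylamino group for one that brings a six-membered aromatic ring, an isopropyl group and a hydrogen-bond donor all at once, so the compounds shown cannot say which of these parts carries the gain. Going by these compounds, a plain phenylamino group without the isopropyl, a benzylamino group, or a cyclic amine such as morpholine at the same carbon would begin to separate them, and how far the number can fall at this position remains open.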